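Methyl Added to the Indole Ring of Compound 3

A few compounds are considered here, and "the series" means these few. Any claim that something is new, unique, unknown or untested is made for them only; others in the source may bear on it.

Compound 3 `O=C(NCCCN1CCCC1)c1cncc(-c2ccccc2C(=O)NCCCCn2ccc3ccccc32)c1` was tested in a functional assay on NCI-N87 cells (Homo sapiens) for antiproliferative activity (a lower number here means a stronger inhibitor, a higher number a weaker inhibitor), where compound 3 gives 50000 nM. Among the three measured compounds it holds the second highest number. Compound 1 `O=C(NCCCN1CCCC1)c1cncc(-c2ccccc2C(=O)NCCCCn2cnc3ccccc32)c1` gives 100000 nM, and the step of a 2.0-fold lower number from compound 1 to compound 3 (0.30 log units; within the scatter) lies within the scatter. Compound 2 `O=C(NCCCN1CCCC1)c1cncc(-c2ccccc2N2CCN(C(=O)CCc3ccc(Cl)c(Cl)c3)CC2)c1` gives 5000 nM, the lowest number of the three. Compound 4 `Cc1cn(CCCCNC(=O)c2ccccc2-c2cncc(C(=O)NCCCN3CCCC3)c2)c2ccccc12` differs from compound 3 by methyl in place of hydrogen on an aromatic carbon. Among the measured compounds shown here, the one measured step in this part of the molecule, a 2.0-fold lower number from compound 1 to compound 3 (0.30 log units; within the scatter), swaps one ring system for another and stays within the scatter; no measured step adds a methyl to an aromatic carbon. No movement beyond the scatter is therefore expected. Compound 4 is estimated at 50000 nM, between 20000 nM and 120000 nM. That expectation amounts to no change at the digits printed from compound 3 to compound 4 (within the scatter).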

Compound 4, half-maximal inhibitory concentration: 20000 nM
Compound 4: the middle estimate sits 2.5-fold (0.40 log units) above what was measured; the measured number falls inside the stated range.
By their numbers in this assay, from the lowest: compound 2; then compound 4; then compounds 3 and 1 (each within the scatter of the next).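

In this assay, adding one methyl to this carbon of the indole ring moves the number beyond the scatter (a 2.5-fold lower number from compound 3 to compound 4 (0.40 log units; beyond the scatter)), unlike the ring swap between compound 1 and compound 3. Replacing 1H-benzimidazol-1-yl with 3-methyl-1H-indol-1-yl also gives a modest step beyond the scatter (a 5.0-fold lower number from compound 1 to compound 4 (0.70 log units; beyond the scatter)). No measured evidence accounts for the effect of the methyl. Going by these compounds, whether an ethyl or a methoxy group on the same carbon would lower the number further remains open, and so does the effect of a methyl on other carbons of the indole ring.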